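Aryl change from compound 3 to compound 4

The source may hold more compounds than are shown below. What is called first, only, known or untested is meant among the compounds shown, and "the series" means these compounds.

In a functional assay on A549 cells (Homo sapiens) for cytotoxicity, read by MTT assay, with a stated time of 72 h (a higher number here means a weaker inhibitor, a lower number a stronger inhibitor), compound 1 (`O=C(Nc1ccc(Oc2ncnc3[nH]ccc23)c(F)c1)c1cc2cccnc2n(-c2ccc(Cl)cc2)c1=O`) gives 35500 nM, compound 2 (`O=C(Nc1ccc(Oc2ncnc3[nH]ccc23)c(F)c1)c1cc2cccnc2n(-c2ccc(Br)cc2)c1=O`) gives 27300 nM and compound 3 (`O=C(Nc1ccc(Oc2ncnc3[nH]ccc23)c(F)c1)c1cc2cccnc2n(-c2ccc(Br)cc2F)c1=O`) gives 218000 nM, the highest of the three numbers. Compound 4 (`O=C(Nc1ccc(Oc2ncnc3[nH]ccc23)c(F)c1)c1cc2cccnc2n(-c2ccc(C(F)(F)F)cc2Cl)c1=O`) keeps the shared core and differs from compound 3 as follows: 2-chloro-4-(trifluoromethyl)phenyl in place of 4-bromo-2-fluorophenyl on an aromatic nitrogen. This places 2-chloro-4-(trifluoromethyl)phenyl in place of 4-bromo-2-fluorophenyl on an aromatic nitrogen.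

Among the compounds with values here, three steps bear on this change. Bromo in place of chloro gives a 1.3-fold lower number from compound 1 to compound 2 (0.11 log units; within the scatter), so that halogen swap shows no measurable effect. Fluoro in place of hydrogen gives an 8.0-fold higher number from compound 2 to compound 3 (0.90 log units; beyond the scatter), and the change of aryl group gives a 6.1-fold higher number from compound 1 to compound 3 (0.79 log units; beyond the scatter). Within the data shown here, no measured step covers trifluoromethyl, or chloro in place of fluoro on this ring, so the evidence is thin. Compound 4 is expected to fall between the two levels seen so far, with a modest move down from compound 3. The estimated step is a 2.4-fold lower number from compound 3 to compound 4 (0.38 log units; beyond the scatter). For compound 4 the estimated value is 90000 nM, with an expected range of 25000 nM to 300000 nM.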

Compound 4, half-maximal inhibitory concentration: 283000 nM
The estimate for compound 4 lay 3.1-fold (0.50 log units) below the measured number, and the stated range covers the measured number.
By their numbers in this assay, from the lowest: compounds 2 and 1 (each within the scatter of the next); then compounds 3 and 4 (each within the scatter of the next).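

In this assay, replacing one disubstituted aryl group on the aromatic nitrogen with another gives a 1.3-fold higher number from compound 3 to compound 4 (0.11 log units; within the scatter), so 2-chloro-4-(trifluoromethyl)phenyl and 4-bromo-2-fluorophenyl cannot be told apart here. Against the singly halogenated aryl groups, the new group gives a 10-fold higher number from compound 2 to compound 4 (1.02 log units; beyond the scatter) and an 8.0-fold higher number from compound 1 to compound 4 (0.90 log units; beyond the scatter), which places compounds 3 and 4 at one level and compounds 1 and 2 at a lower one, with none of the four going against this split. No measurement shown accounts for the split.

A 4-(trifluoromethyl)phenyl group without the chloro would separate the two differences between compound 4 and the singly halogenated compounds. Also open, from the compounds shown here alone, is how this position reads with a methoxy, an amine or a carboxylic acid on the aryl ring in place of a halogen.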